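The compounds below may be only part of what the source reports. "The series", "measured", "known", "first", "only" and "open" are said of these compounds alone.

Measured compounds:
Compound 1, `Cc1noc(-c2nc(C)c3c(c2N)C(=O)N(Cc2cccc(F)c2)C3=O)n1`: in a physicochemical assay for solubility, using the shake flask method, in simulated intestinal fluid, measured as kinetic solubility, with a stated time of 2 h, at 25 degrees C, at pH 6.5 (on this read-out higher numbers stand for higher solubility and lower numbers for lower solubility), compound 1 gives < 5000 nM, which is a limit of the assay and not a number.
Compound 2, `Cc1noc(-c2nc(C)c3c(c2N)C(=O)N(C(C)c2ccccc2)C3=O)n1`: in this assay compound 2 gives 10900 nM.

Compound 1 therefore stands only at the limit of < 5000 nM in this assay, at which 1 of the 2 values shown sits. Compound 3, `Cc1noc(-c2nc(C)c3c(c2N)C(=O)N(Cc2ccc(N(C)C)cc2)C3=O)n1`, differs from compound 1 by 4-(dimethylamino)phenyl in place of 3-fluorophenyl on a saturated chain carbon bound to an amide-type nitrogen in a ring. Among the compounds with values here, the single measured step at this position, an at least 2.1-fold higher number from compound 1 to compound 2 (0.33 log units; beyond the scatter), shows that exchanging the group on the amide-type nitrogen did move solubility. A rise of similar size is expected here, namely an at least 1.6-fold higher number from compound 1 to compound 3 (0.20 log units; that floor lies within the scatter). Compound 3 is estimated at 8000 nM, with a range from 2500 nM to 30000 nM.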

Compound 3, solubility: 7400 nM
Beside the measured number, compound 3's estimate is 1.1-fold (0.03 log units) above it; measured number inside the range.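

In this assay, exchanging only the aromatic group on the saturated chain carbon, 4-(dimethylamino)phenyl in place of 3-fluorophenyl, gives an at least 1.4-fold higher number from compound 1 to compound 3 (0.17 log units; that floor lies within the scatter). A rise at this position therefore need not depend on changing the chain carbon itself, as in the 1-phenylethyl step, but this change alone does not establish one. The reading for compound 1 is a limit of the assay and not a number, so the true size of the step stays unknown: the limit of < 5000 nM in this assay, at which 1 of the 3 values shown sits.

Open, from the compounds shown here alone, is how a morpholine or a carboxylic acid on that aromatic ring would read. Going by these compounds, a longer chain on the amide-type nitrogen is equally open.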